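The compounds below may be only part of what the source reports. "The series", "measured", "known", "first", "only" and "open" are said of these compounds alone.

Compound 1, `Cc1ccccc1-c1cc(C(=O)N2CCC3(CC2)CC(=O)c2nn(C(C)(C)C)cc2O3)c2ccccc2n1`: 1880 nM
Compound 2, `CC(C)(C)n1cc2c(n1)C(=O)CC1(CCN(C(=O)c3cc(-c4ccccc4Cl)nc4ccccc34)CC1)O2`: 2180 nM
Compound 3, `COc1ccc(-c2cc(C(=O)N3CCC4(CC3)CC(=O)c3nn(C(C)(C)C)cc3O4)c3ccccc3n2)cc1`: 3740 nM

All three compounds share one core and differ only in the aryl group attached to it. In a functional assay on A549 cells (Homo sapiens) for inhibition, read by MTT assay, with a stated time of 72 h (on this read-out higher numbers stand for weaker inhibition and lower numbers for stronger inhibition), compound 1 gives the lowest of the three numbers, but its nearest neighbour is compound 2, with a 1.2-fold higher number from compound 1 to compound 2 (0.06 log units; within the scatter), and its furthest is compound 3, with a 2.0-fold higher number from compound 1 to compound 3 (0.30 log units; within the scatter), so the three cannot be told apart beyond the scatter.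

Compound 4, `CC(C)(C)n1cc2c(n1)C(=O)CC1(CCN(C(=O)c3cc(-c4ccc(N)cc4)nc4ccccc34)CC1)O2`, has not yet been measured in this assay. It differs from compound 1 in one place: 4-aminophenyl in place of 2-methylphenyl on an aromatic carbon.

For the measured compounds named here, the step that bears most on this change is the one from compound 1 to compound 3, where a para-substituted phenyl also took the place of 2-methylphenyl, giving a 2.0-fold higher number from compound 1 to compound 3 (0.30 log units; within the scatter). The step from compound 2 to compound 3, a 1.7-fold higher number from compound 2 to compound 3 (0.23 log units; within the scatter), points the same way. Both stayed within the scatter. Going by the values given here, the 4-aminophenyl group brings a hydrogen-bond donor and acceptor that none of the measured groups carries, so there is no direct guide for that part of the change.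

Compound 4 is therefore expected to give a number close to that of compound 1, with a 1.6-fold higher number from compound 1 to compound 4 (0.20 log units; within the scatter), and its estimated value is 3000 nM, lying between 1200 nM and 8000 nM.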

Compound 4, half-maximal inhibitory concentration: 970 nM
Compound 4: the middle estimate sits 3.1-fold (0.49 log units) above what was measured; measured number below the stated range.
By their numbers in this assay, from the lowest: compounds 4, 1, 2 and 3 (each within the scatter of the next, the first and the last beyond it).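

In this assay, for the compounds shown here, the exchange of methoxy for amino, with the rest of the molecule unchanged, gives a 3.9-fold lower number from compound 3 to compound 4 (0.59 log units; beyond the scatter), so a change to a single group on this phenyl ring can move the number beyond the scatter, which no step among the earlier compounds did. The exchange of 2-chlorophenyl for 4-aminophenyl also passes the scatter, with a 2.2-fold lower number from compound 2 to compound 4 (0.35 log units; beyond the scatter), whereas the exchange of 2-methylphenyl for 4-aminophenyl, with a 1.9-fold lower number from compound 1 to compound 4 (0.29 log units; within the scatter), stays within it, so compound 1 and compound 4 cannot be told apart. Going by these compounds alone, this position therefore does respond to the choice of aryl group, but only modestly, and compound 1 shows that 4-aminophenyl is not the only group here that gives a number in this range.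

Nothing measured here explains the gap between the amino and methoxy compounds. The compounds shown also leave open whether the free amino group itself matters, a question that a dimethylamino, hydroxyl or acetamido group in its place on the phenyl ring, or a 2-aminophenyl or 3-aminophenyl group at this position, could help to answer.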